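Cytotoxicity notes: aryl versus hydroxyalkyl amine on the core

The source may hold more compounds than are shown below. What is called first, only, known or untested is meant among the compounds shown, and "the series" means these compounds.

Measured compounds in an ADME assay on THP-1 cells (Homo sapiens) for cytotoxicity; a lower number here means that less compound is tolerated, a higher number that more compound is tolerated:
Compound 1 `c1ccc(-c2nc3ccccn3c2Nc2ccc3c(c2)OCCO3)nc1` gives 25600 nM.
Compound 2 `Clc1ccc2nc(-c3ccccn3)c(Nc3ccc4c(c3)OCCO4)n2c1` gives only a limit of the assay, > 50000 nM.
Compound 3 `CC(C)(O)CNc1c(-c2ccccn2)nc2ccccn12` gives only a limit of the assay, > 50000 nM.

Compound 3 carries a 2-hydroxy-2-methylpropyl group on the nitrogen on an aromatic ring and sits at the limit of > 50000 nM in this assay, at which 2 of the 3 values shown sit, so no number is known for it, only that it lies past the limit. Compound 4 `N#Cc1ccc(Nc2c(-c3ccccn3)nc3ccccn23)cc1` differs from compound 3 in one place: 4-cyanophenyl in place of 2-hydroxy-2-methylpropyl on a nitrogen on an aromatic ring.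

Going by the values given here, the only step measured is an at least 1.9-fold higher number from compound 1 to compound 2 (0.29 log units; that floor lies within the scatter), a change of chloro for hydrogen on the core; it does not concern the nitrogen substituent and so gives no direct guidance for the present change. What is known is that compound 1, which carries an aromatic ring on that nitrogen, gives a number of 25600 nM. The hydroxyalkyl analogue compound 3 gives only a limit of the assay. On that basis compound 4, with an aromatic ring at the same place, is expected to fall near compound 1, the estimated step being an at least 1.6-fold lower number from compound 3 to compound 4 (0.22 log units; that floor lies within the scatter), though the limit on compound 3 makes the size uncertain. The expected value for compound 4 in this assay is therefore 30000 nM, with a range from 8000 nM to 60000 nM.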

Compound 4, half-maximal cytotoxic concentration: > 50000 nM
Compound 4 gave a limit, no number; the forecaster's own chance of this, stated with the estimate: 35%; middle value at least 1.6-fold (0.22 log units) away from the limit.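

In this assay compound 4 gives > 50000 nM, a limit of the assay. Compound 3 gives > 50000 nM, also a limit, so no step can be read between compound 3 and compound 4. It remains open whether 4-cyanophenyl in place of 2-hydroxy-2-methylpropyl on the nitrogen changes the read-out at all, with most values shown sitting at one limit: the limit of > 50000 nM in this assay, at which 3 of the 4 values shown sit.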